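The source may hold more compounds than are shown below. What is called first, only, known or untested is meant among the compounds shown, and "the series" means these compounds.

In an ADME assay on MT4 cells (Homo sapiens) for cytotoxicity, read by MTT assay, with a stated time of 4 days (on this read-out higher numbers stand for lower toxicity in this test and lower numbers for higher toxicity in this test), compound 3 (`COc1ccc(-c2oc3ccc(N)cc3c(=O)c2OC)cc1`) gives 200000 nM. That value lies within the scatter of both neighbouring results: compound 1 (`Nc1ccc2oc(-c3ccc(F)cc3)cc(=O)c2c1`) gives 264000 nM and compound 2 (`COc1c(-c2ccccc2)oc2ccc(N)cc2c1=O`) gives 126000 nM.

The next structure is compound 4 (`COc1c(-c2ccc(F)cc2)oc2ccc(N)cc2c1=O`), which has fluoro in place of methoxy on an aromatic carbon, para to a large group (fluoro in place of methoxy on an aromatic carbon). Within the data shown here, the only measured step at that carbon is a 1.6-fold higher number from compound 2 to compound 3 (0.20 log units; within the scatter), where methoxy replaces hydrogen, and it stays within the scatter. Among the measured compounds shown here, no measured step isolates fluoro: compound 1 carries it but also lacks the second methoxy found in compound 4, so it offers only indirect support. The three values sit close together, and no step beyond the scatter is expected in this assay.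

The expected step is a 1.1-fold lower number from compound 3 to compound 4 (0.05 log units; within the scatter), an estimate that remains within the scatter. For compound 4, the estimated value is 180000 nM, with an expected range of 100000 nM to 300000 nM.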

Compound 4, half-maximal cytotoxic concentration: 141000 nM
For compound 4 the middle estimate is 1.3-fold (0.11 log units) above the measured one; the measured number falls inside the stated range.
By their numbers in this assay, from the lowest: compounds 2, 4, 3 and 1 (each within the scatter of the next, the first and the last beyond it).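

In this assay, fluoro at this carbon, para to a large group, can now be read against both methoxy and hydrogen: a 1.4-fold lower number from compound 3 to compound 4 (0.15 log units; within the scatter), and a 1.1-fold higher number from compound 2 to compound 4 (0.05 log units; within the scatter). Hydrogen, methoxy and fluoro at this place therefore do not separate from one another beyond the scatter on this core. Methoxy in place of hydrogen on an aromatic carbon now has a second reading, a 1.9-fold lower number from compound 1 to compound 4 (0.27 log units; within the scatter), and the two readings do not carry over from one core to the other, although each step alone stays within the scatter: the same change on two cores in this assay, a 1.6-fold higher number (0.20 log units; within the scatter) from compound 2 to compound 3 and a 1.9-fold lower number (0.27 log units; within the scatter) from compound 1 to compound 4, 3.0-fold (0.47 log units) apart, beyond the scatter of two such steps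

Going by these compounds, whether any group at this carbon can move the number beyond the scatter stays open, as does what an amine, a carboxylic acid or a longer alkoxy chain would do there. On these data alone, whether the gap between the two methoxy steps would recur on further cores also stays open.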